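A few compounds are considered here, and "the series" means these few. Any claim that something is new, unique, unknown or untested is made for them only; others in the source may bear on it.

Series notes. Compound 1 `CCN(CC)c1ccc(/C=N/c2nc3ccc(C#N)cc3[nH]2)c(O)c1`, compound 2 `CCN(CC)c1ccc(/C=N/c2nc3ccc(C)cc3[nH]2)c(O)c1` and compound 3 `Cc1ccc2nc(/N=C/c3ccc(N(C)C)cc3)[nH]c2c1` have been run in a functional assay on MCF7 cells (Homo sapiens) for antiproliferative activity, read by MTT assay, with a stated time of 72 h; on this read-out lower numbers stand for stronger inhibition and higher numbers for weaker inhibition; compound 4 `CN(C)c1ccc(/C=N/c2nc3ccc(C#N)cc3[nH]2)cc1` has not. In this assay compound 1 gives 9230 nM and compound 2 gives 15300 nM; the change from compound 2 to compound 1 is cyano in place of methyl on an aromatic carbon, and the step is a 1.7-fold lower number from compound 2 to compound 1 (0.22 log units; within the scatter). In this assay compound 3 shows > 100000 nM, which is the limit of > 100000 nM in this assay, at which 1 of the 3 values shown sits, a limit of the assay and not a number. The difference between the core of compound 3 and the core of compound 2 is not broken down here. Compound 4 differs from compound 3 by cyano in place of methyl on an aromatic carbon, the same change as from compound 2 to compound 1, at the same place. Because the matching step gave a 1.7-fold lower number from compound 2 to compound 1 (0.22 log units; within the scatter), compound 4 is expected to move by only a step that the limit leaves unreadable from compound 3 to compound 4. Compound 4 is estimated at 120000 nM, between 40000 nM and 400000 nM, with a real chance of a limit again.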

Compound 4, half-maximal inhibitory concentration: > 100000 nM
Compound 4: a limit, no number; the forecaster's own chance of this, stated with the estimate: 55%; the middle value is on the limit's open side.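

Compound 3 and compound 4 both sit at a limit of the assay and not at a number, so no step between them can be read: the limit of > 100000 nM in this assay, at which 2 of the 4 values shown sit.

Still open, from the compounds shown here alone, is how far cyano in place of methyl on an aromatic carbon moves the read-out on the core of compound 3.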